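Compound 3: Swapping a Hexyl Chain for an Aryl Alkene

This account rests on a few compounds, and the source may have more. Where it says the series, first, only, none or still open, it means among the compounds named here.

- Compound 1 `Clc1ccc(CCCN2CCC(COC(c3ccccc3)c3ccccc3)CC2)cc1Cl` gives 2200 nM
- Compound 2 `CCCCCCCN1CCC(COC(c2ccccc2)c2ccccc2)CC1` gives 500 nM

In a functional assay on cells (T-cell line, Homo sapiens) for inhibition (on this read-out higher numbers stand for weaker inhibition and lower numbers for stronger inhibition), compound 2 has the lower of the two numbers, which makes it the stronger inhibitor so far. Compound 3 `COc1ccc(/C=C/CN2CCC(COC(c3ccccc3)c3ccccc3)CC2)cc1` differs from compound 2 in one place, on a saturated chain carbon bound to an amine nitrogen in a ring: 2-(4-methoxyphenyl)ethenyl in place of hexyl on a saturated chain carbon bound to an amine nitrogen in a ring.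

Among the measured compounds shown here, only one measured step bears on this change: a 4.4-fold lower number from compound 1 to compound 2 (0.64 log units; beyond the scatter). That modest step replaced 3,4-dichlorophenyl with butyl. Compound 3 regains an aromatic ring, as in compound 1 at 2200 nM, so a move back toward a higher number is expected. For the measured compounds named here, one step is thin evidence, and no measured compound carries the 2-(4-methoxyphenyl)ethenyl group.

The expected change is a 2.4-fold higher number from compound 2 to compound 3 (0.38 log units; beyond the scatter). For compound 3 the estimate is 1200 nM, with an expected range of 350 nM to 4000 nM.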

Compound 3, half-maximal inhibitory concentration: 4300 nM
Estimate against measurement, compound 3: 3.6-fold (0.55 log units) below, outside the stated range (above it).
By their numbers in this assay, from the lowest: compound 2; then compounds 1 and 3 (each within the scatter of the next).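

In this assay, the step with 2-(4-methoxyphenyl)ethenyl in place of hexyl is an 8.6-fold higher number from compound 2 to compound 3 (0.93 log units; beyond the scatter), so among these three compounds, the plain alkyl chain of compound 2 has the lowest number, and both compounds with an aromatic ring at this position sit higher. The two aromatic groups differ in their ring substituents and in the double bond, yet the step between them is a 2.0-fold higher number from compound 1 to compound 3 (0.29 log units; within the scatter), so this assay does not separate them. No measurement here gives a reason for either step.

From the compounds shown here alone, it remains open whether the aromatic ring alone sets the higher number, or whether the double bond and the methoxy group also contribute. An unsubstituted 3-phenylpropyl group would test the ring by itself, and a longer alkyl chain or a chain ending in an amine would show how far this position tolerates other groups.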